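This account rests on a few compounds, and the source may have more. Where it says the series, first, only, none or still open, it means among the compounds named here.

Working notes on the series in a functional assay on CCRF-CEM cells (Homo sapiens) for cytotoxicity, in the absence of a further agent; on this read-out higher numbers stand for weaker inhibition and lower numbers for stronger inhibition.

Compound 3 `COC(=O)c1ccc(CN(CCCc2c(N)nc(N)nc2O)c2cc(F)ccc2[N+](=O)[O-])cc1` gives 43000 nM. Compound 1 `COC(=O)c1ccc(CN(CCCc2c(N)nc(N)nc2O)c2ccc([N+](=O)[O-])c(F)c2F)cc1` carries the change 2,3-difluoro-4-nitrophenyl in place of 5-fluoro-2-nitrophenyl on an amine nitrogen and gives 45000 nM; the step of a 1.0-fold higher number from compound 3 to compound 1 (0.02 log units; within the scatter) is the one result so far for this change. Compound 2 `CC(C)(C)OC(=O)CCC(Nc1ccc(CN(CCCc2c(N)nc(N)nc2O)c2cc(F)ccc2[N+](=O)[O-])cc1)C(=O)OC(C)(C)C` gives 3400 nM, the lowest of the three numbers; the difference between its core and that of compound 3 is not broken down here, and the two cores are compared only through their values.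

Compound 4 `CC(C)(C)OC(=O)CCC(Nc1ccc(CN(CCCc2c(N)nc(N)nc2O)c2ccc([N+](=O)[O-])c(F)c2F)cc1)C(=O)OC(C)(C)C` is not yet measured. It carries 2,3-difluoro-4-nitrophenyl in place of 5-fluoro-2-nitrophenyl on an amine nitrogen, the same change as from compound 3 to compound 1, at a place described in the same words. Within the data shown here, the only measured step of this kind, a 1.0-fold higher number from compound 3 to compound 1 (0.02 log units; within the scatter), stays within the scatter. On that ground the same is expected here, giving an estimated 1.0-fold higher number from compound 2 to compound 4 (0.01 log units; within the scatter). Compound 4 is therefore estimated at 3500 nM, between 1500 nM and 9000 nM.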

Compound 4, half-maximal inhibitory concentration: 36000 nM
The estimate for compound 4 lay 10-fold (1.01 log units) below the measured number; the whole stated range lies below it.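

In this assay, 2,3-difluoro-4-nitrophenyl in place of 5-fluoro-2-nitrophenyl on an amine nitrogen gives an 11-fold higher number from compound 2 to compound 4 (1.02 log units; beyond the scatter), so the change does not carry over unaltered from one core to the other: the same change on two cores in this assay, a 1.0-fold higher number (0.02 log units; within the scatter) from compound 3 to compound 1 and an 11-fold higher number (1.02 log units; beyond the scatter) from compound 2 to compound 4, 10-fold (1.01 log units) apart, beyond the scatter of two such steps. In these two pairs, the outcome of the change depends on the core that carries it. Two pairs give no rule for further cores, and they do not show which part of the core of compound 2 sets it apart or why the steps differ.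

As far as these compounds go, it remains open how the same change behaves on a core with carboxylic acids in place of the ester groups of compound 2. From the compounds shown here alone, the outcome with an amine in place of those esters is equally open.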